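Trimming the amide chain of compound 1

This account rests on a few compounds, and the source may have more. Where it says the series, first, only, none or still open, it means among the compounds named here.

- compound 1 `CCCCCCNC(=O)/C=C/c1ccccc1`: 82%
- compound 2 `CC(C)=CCC/C(C)=C/COC(=O)/C=C/c1ccc(Cl)cc1Cl`: 1%

In a functional assay on the whole organism for inhibition, with Brassica rapa subsp. chinensis as the target, with a stated time of 3 days, tested at 100 ppm (a higher number here means more inhibition of growth at the concentration tested, a lower number less inhibition of growth), compound 1 stands higher of the two measured compounds at 82% and compound 2 lies at 1% with the gap beyond the usual scatter. The next compound to be read is compound 3 `CCCCCNC(=O)/C=C/c1ccccc1` which differs from compound 1 in one place: hydrogen in place of methyl on a saturated chain carbon, five bonds along the chain from an amide-type nitrogen. For the measured compounds named here, no measured pair shows a change of this kind, so the expectation rests only on how small the change is. The expected result is a number 7 percentage points lower from compound 1 to compound 3 (within the scatter) as a small downward step in this assay that probably stays within the scatter. Compound 3 is estimated at 75% (expected range 50% to 92%) in this read-out.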

Compound 3, percent growth inhibition at one concentration: 76%
Compound 3: middle estimate off by 1 percentage points, on the low side, within the range that was stated.
By their numbers in this assay, from the lowest: compound 2; then compounds 3 and 1 (each within the scatter of the next).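

Hydrogen in place of methyl on a saturated chain carbon, five bonds along the chain from an amide-type nitrogen, gives a number 6 percentage points lower from compound 1 to compound 3 (within the scatter) in this assay. For the compounds shown here, this is the first single-place step, and it shows that the growth-inhibition read-out does not separate the two chain lengths, so this methyl is not needed to keep compound 3 in the same range as compound 1. No measurement on hand bears on why the read-out holds across this change.

One step at one position says nothing about how far the chain can be trimmed, or whether a longer chain would read the same. Also open, from the compounds shown here alone, is whether an amine or a carboxylic acid on this chain carbon would be accepted in place of the methyl.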